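The compounds below may be only part of what the source reports. "The series", "measured", "known", "first", "only" and "open" are said of these compounds alone.

Compound 1 `Cc1nc2ccccc2c(=O)n1NC(=O)NC1CCCCC1`: 12%
Compound 2 `Cc1ccc(S(=O)(=O)Nn2c(C)nc3ccccc3c2=O)cc1`: 3.2%

In a functional assay on the whole organism (strain Sprague-Dawley) for inhibition, with Rattus norvegicus as the target, read by paw edema, with stated times of 30 min and 1 h, at a dose of 80 mg/kg by the oral route (on this read-out lower numbers stand for less inhibition and higher numbers for more inhibition at the one dose given (going by the name of the read-out)), compound 1 gives 12%. Compound 2 gives 3.2%, a number that lies within the usual scatter of the first, so the two measured compounds cannot be told apart on these numbers. Compound 3 `O=C(NC1CCCCC1)Nn1c(CO[N+](=O)[O-])nc2ccccc2c1=O` differs from compound 1 in one place: nitrooxy in place of hydrogen on a saturated chain carbon bound to an aromatic carbon. Within the data shown here, no step between two measured compounds is known, so nothing measured tells what such a change does here. The step of a number 3 percentage points higher from compound 1 to compound 3 (within the scatter) is expected to stay within the scatter, with no clear direction. Compound 3 is therefore estimated to give 15%, in the range 4% to 30%.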

Compound 3, a percentage reported as inhibition, in the whole organism at one dose (the size of the read-out at that dose, not a potency): 8%
Beside the measured number, compound 3's estimate is 7 percentage points above it; low and high end bracket the measured number.
By their numbers in this assay, from the lowest: compounds 2, 3 and 1 (each within the scatter of the next).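

Among these compounds, the step of a number 4 percentage points lower from compound 1 to compound 3 (within the scatter) in this assay is the first measured step at this position, and it shows that nitrooxy in place of hydrogen on a saturated chain carbon bound to an aromatic carbon leaves compound 1 and compound 3 indistinguishable at this dose. Nothing available bears on the reason for this result. As far as these compounds go, whether an amine or a carboxylic acid on that carbon, or a longer chain in place of the methyl, would give a number beyond the scatter remains open. Also open, from the compounds shown here alone, is whether nitrooxy would behave the same way on compound 2.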